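Methoxy in Place of Methyl: Expecting No Gain

A few compounds are considered here, and "the series" means these few. Any claim that something is new, unique, unknown or untested is made for them only; others in the source may bear on it.

Compound 1 `Cc1ccc(C(=O)c2ccc3c(ccn3Cc3ccc(C(=O)NO)cc3)c2)cc1` was tested in an assay on isolated protein for inhibition of polyamine deacetylase HDAC10 (Homo sapiens); on this read-out lower numbers stand for stronger inhibition and higher numbers for weaker inhibition. In this assay compound 1 gives > 100000 nM, which is a limit of the assay rather than a number. Two related compounds were measured in the same way. Compound 2 `COc1ccc(C(=O)c2ccc3c(ccn3S(=O)(=O)c3ccc(/C=C/C(=O)NO)cc3)c2)cc1` gives > 100000 nM, again a limit. Compound 3 `COc1cc(C(=O)c2ccc3c(ccn3S(=O)(=O)c3cccc(/C=C/C(=O)NO)c3)c2)cc(OC)c1OC` gives > 100000 nM, also a limit. So every value shown sits at the same point, and compound 1 stands there alongside the others; the picture is summed up by the limit of > 100000 nM in this assay, at which 3 of the 3 values shown sit.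

Compound 4 `COc1ccc(C(=O)c2ccc3c(ccn3Cc3ccc(C(=O)NO)cc3)c2)cc1` is not yet measured. It differs from compound 1 by a single change methoxy in place of methyl on an aromatic carbon: a methoxy group replaces a methyl group on an aromatic carbon, para to a large group. Since compound 1 and compound 2 both sit at the limit, no step beyond the usual scatter is expected from this change in either direction. The expected step from compound 1 to compound 4 is a step that the limit leaves unreadable from compound 1 to compound 4, essentially no movement. Compound 4 is therefore estimated at 150000 nM, most likely reported again only as a limit, with a range from 50000 nM to 500000 nM.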

Compound 4, half-maximal inhibitory concentration: 59800 nM
Compound 4: the middle estimate sits 2.5-fold (0.40 log units) above what was measured; the range from low to high includes it.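

In this assay compound 4 gives 59800 nM, the first result in this set that is a number and not a limit. Methoxy in place of methyl on this aromatic carbon, para to a large group, gives an at least 1.6-fold lower number from compound 1 to compound 4 (0.22 log units; that floor lies within the scatter), so the change moves the read-out to a measurable value, although only a floor for the step is known and the true step may be small or much larger. That floor is all that can be read, and a measured value remains the exception here: the limit of > 100000 nM in this assay, at which 3 of the 4 values shown sit.

Going by these compounds, it remains open whether an ethoxy, a hydroxyl, an amine or a carboxylic acid on this same carbon would lower the number further. On these data alone, it is also open whether the change from methyl to methoxy would have a similar effect on a different core.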